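Acetamido on the phenoxy ring: compound 4 from compound 2

The source may report more compounds than this note shows. Statements on the series, on what has been measured and on what is new or still open speak of the compounds shown alone.

Compound 1, `CC(C)[C@H](NC(=O)COc1cccc2ccccc12)C(=O)N[C@@H](CC(=O)O)C(=O)COC(=O)c1c(Cl)cccc1Cl`, gives 10600 nM in a functional assay on Jurkat cells (Homo sapiens); on this read-out lower numbers stand for stronger inhibition and higher numbers for weaker inhibition.
Compound 2, `CC(C)[C@H](NC(=O)COc1cccc2ccccc12)C(=O)N[C@@H](CC(=O)O)C(=O)COc1ccccc1`, gives 14000 nM in this assay.
Compound 3, `CC(C)[C@H](NC(=O)COc1cccc2ccccc12)C(=O)N[C@@H](CC(=O)O)C(=O)COc1ccc(C(N)=O)cc1`, gives only a limit of > 100000 nM in this assay.

Among the two numbers in this assay, compound 2 has the highest; its nearest neighbour is compound 1, and the step of a 1.3-fold higher number from compound 1 to compound 2 (0.12 log units; within the scatter) lies within the scatter. Compound 3 gives no number but a limit (the limit of > 100000 nM in this assay, at which 1 of the 3 values shown sits), and it is reached by the step of an at least 7.1-fold higher number from compound 2 to compound 3 (0.85 log units; beyond the scatter), as well as by an at least 9.4-fold higher number from compound 1 to compound 3 (0.97 log units; beyond the scatter).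

Compound 4, `CC(=O)Nc1cccc(OCC(=O)[C@H](CC(=O)O)NC(=O)[C@@H](NC(=O)COc2cccc3ccccc23)C(C)C)c1`, has not yet been measured in this assay. It differs from compound 2 in one place: acetamido in place of hydrogen on an aromatic carbon. Within the data shown here, the step that bears on this is the one from compound 2 to compound 3, where a carbamoyl enters on an aromatic carbon of the same ring and the number rises beyond the scatter, by an at least 7.1-fold higher number from compound 2 to compound 3 (0.85 log units; beyond the scatter). An acetamido group entering on the same ring, meta to a large group, is therefore expected to move the number in the same direction, with a step of about a 3.6-fold higher number from compound 2 to compound 4 (0.55 log units; beyond the scatter). Compound 4 is accordingly estimated at 50000 nM, in a range from 15000 nM to 200000 nM, with a fair chance that only a limit is reported.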

Compound 4, half-maximal inhibitory concentration: > 100000 nM
Compound 4: a limit, no number; the forecaster's own chance of this, stated with the estimate: 40%; at least 2.0-fold (0.30 log units) between middle value and limit.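

The change from phenoxy to 3-acetamidophenoxy takes the result in this assay from a measured number to a limit, with an at least 7.1-fold higher number from compound 2 to compound 4 (0.85 log units; beyond the scatter), and the comparison with the other measured compound gives an at least 9.4-fold higher number from compound 1 to compound 4 (0.97 log units; beyond the scatter). The earlier compounds shown here showed this kind of loss only for the carbamoyl of compound 3, whereas compound 4 shows it for a second group, acetamido, placed on an aromatic carbon of the phenoxy ring, meta to a large group, so the loss is not confined to one substituent at one place. Compound 3 and compound 4 each give only a limit, so the step between them cannot be read and the two groups cannot be ranked, and the top of the range now holds both of them: the limit of > 100000 nM in this assay, at which 2 of the 4 values shown sit.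

On these data alone, how far beyond the limit compound 3 and compound 4 lie remains open. The compounds shown also leave open whether the loss follows any group on this ring or only these two, which a methoxy group, a chlorine atom, an amine or a carboxylic acid at the same place could help to separate.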